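Swapping the pyridylmethyl arm for a tert-butoxycarbonyl group

The compounds below may be only part of what the source reports. "The series", "measured", "known", "first", "only" and "open" are said of these compounds alone.

Compound 1 `O=[N+]([O-])c1ccc(C2=NOC(c3ccc(N4CCN(Cc5ccccn5)CC4)cc3)C2)o1` was examined in an ADME assay on HeLa cells (Homo sapiens) for cytotoxicity, read by MTT assay, with a stated time of 96 h; a lower number here means a stronger inhibitor, a higher number a weaker inhibitor. In this assay compound 1 reaches only the limit of the method, > 50000 nM, and no number is reported. Compound 2 `O=[N+]([O-])c1ccc(C2=NOC(c3ccc(-c4ccncc4)cc3)C2)o1` shares the same core but carries a different substituent on the phenyl ring. In this assay compound 2 likewise stops at the limit, > 50000 nM, without a number. So compound 1 stands where every value shown stands, namely at the limit of > 50000 nM in this assay, at which 2 of the 2 values shown sit, which leaves its true position open.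

Compound 3 `CC(C)(C)OC(=O)N1CCN(c2ccc(C3CC(c4ccc([N+](=O)[O-])o4)=NO3)cc2)CC1` has not yet been measured in this assay. It differs from compound 1 in one place: tert-butoxycarbonyl in place of (pyridin-2-yl)methyl on an amine nitrogen in a ring. For the measured compounds named here, no step between two measured compounds is available to guide the forecast, and both known values are limits. Any step from compound 1 to compound 3 is therefore expected to stay within the scatter, a step that the limit leaves unreadable from compound 1 to compound 3. Compound 3 is expected to give about 100000 nM in this assay, within a range from 40000 nM to 300000 nM, most probably reported again as a limit rather than a number.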

Compound 3, half-maximal inhibitory concentration: > 50000 nM
Compound 3 was reported as a limit (the forecaster's own chance of this, stated with the estimate: 85%); the middle value does not contradict the limit.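

No step from compound 1 to compound 3 can be read, because both are reported only as limits in this assay: the limit of > 50000 nM in this assay, at which 3 of the 3 values shown sit.

The compounds shown leave open where any of them truly stands in this assay, and whether tert-butoxycarbonyl in place of (pyridin-2-yl)methyl makes any difference there.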